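A few compounds are considered here, and "the series" means these few. Any claim that something is new, unique, unknown or untested is made for them only; others in the source may bear on it.

Compound 1 `CNC(=O)c1cc(Oc2ccc3nc(Nc4ccccc4Br)ncc3c2)ccn1` and compound 2 `CCc1ccccc1Nc1ncc2cc(Oc3ccnc(C(=O)NC)c3)ccc2n1` share one core, the second carrying ethyl in place of bromo on an aromatic carbon. In an ADME assay on Caco-2 cells (Homo sapiens) for permeability, in the apical to basolateral direction (a higher number here means that the compound crosses the layer faster, a lower number that the compound crosses the layer more slowly), compound 1 gives a value that is only a limit, < 1 10^-6 cm/s. Compound 2 likewise reaches only a limit, < 1 10^-6 cm/s. The step that the two limits leave unreadable from compound 1 to compound 2 therefore cannot be read, as the limit of < 1 10^-6 cm/s in this assay, at which 2 of the 2 values shown sit, shows. Compound 3 `CNC(=O)c1cc(Oc2ccc3nc(Nc4ccccc4Oc4ccccc4)ncc3c2)ccn1` carries phenoxy in place of ethyl on an aromatic carbon. Among the compounds with values here, no measured step bears on this change, and compound 2 stands only at a limit. The expected step from compound 2 to compound 3 is a step that the limit leaves unreadable from compound 2 to compound 3. Compound 3 is estimated at 0.7 10^-6 cm/s, with a range from 0.3 10^-6 cm/s to 2 10^-6 cm/s.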

Compound 3, apparent permeability: < 1 10^-6 cm/s
Compound 3: only a limit was reported (the forecaster's own chance of this, stated with the estimate: 70%); the middle value lies beyond the limit too.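

Within the data shown here, compound 3, like compound 1 and compound 2, reaches only a limit, so no step among them can be read in this assay: the limit of < 1 10^-6 cm/s in this assay, at which 3 of the 3 values shown sit. As far as these compounds go, how fast each of the three compounds crosses the layer remains open.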